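This account rests on a few compounds, and the source may have more. Where it says the series, first, only, none or still open, it means among the compounds named here.

Of the compounds shown here, three of a shared core have been tested in a functional assay on cells (T-cell, Homo sapiens) for inhibition (on this read-out higher numbers stand for weaker inhibition and lower numbers for stronger inhibition), and all three sit at the weak end of what that test can show. Compound 1, `CC(C)Oc1nc(N)nc2ncc(-c3ccc(C#N)cc3)nc12`, gives only a limit in this assay, > 10000 nM, which means the test reports no number for it. Compound 2, `COc1ccc(-c2cnc3nc(N)nc(NCc4ccccc4)c3n2)cc1OC`, gives 13000 nM in this assay. Compound 3, `CCOc1nc(N)nc2ncc(-c3ccc(C(F)(F)F)cc3)nc12`, gives 10000 nM in this assay. Where compound 1 stands among these numbers is therefore fixed only by the limit of > 10000 nM in this assay, at which 1 of the 3 values shown sits: its true value is unknown beyond that boundary, and the other two values lie close to the same region.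

Compound 4, `CCOc1ccc(-c2cnc3nc(N)nc(OC(C)C)c3n2)cc1`, has not yet been measured. It differs from compound 1 in one place: ethoxy in place of cyano on an aromatic carbon. For the measured compounds named here, no measured pair in this set shows what such a change does, so there is no step to lean on, and the expectation is that the step in this assay from compound 1 to compound 4 stays within the usual scatter, with no clear direction. Compound 4 is therefore expected to give about 10000 nM in this assay, somewhere between 3000 nM and 30000 nM. That expectation amounts to a step of a number no higher from compound 1 to compound 4 (the limit leaves the size open).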

Compound 4, half-maximal inhibitory concentration: 10000 nM
Compound 4: middle estimate and measured number agree at the digits printed; low and high end bracket the measured number.
By their numbers in this assay, from the lowest: compounds 3, 4 and 2 (each within the scatter of the next).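

With ethoxy in place of cyano on the aromatic carbon, para to a large group, compound 4 gives a real number in this assay, 10000 nM, and this leaves it at the weak end of what this assay can show, so ethoxy at this place brings no strong inhibition. Compound 1 carries only a limit, > 10000 nM. The step reads a number no higher from compound 1 to compound 4 (the limit leaves the size open) and its size therefore cannot be read, and its direction cannot be taken as a real gain, because the comparison rests on that limit: the limit of > 10000 nM in this assay, at which 1 of the 4 values shown sits.

The compounds shown leave open whether any other group at this place, such as an amine, a carboxylic acid or a longer chain, would give a number clearly lower than that of compound 4 in this assay. For the compounds shown here, they also leave open how far cyano and ethoxy truly differ here, since only one side of this pair has a number, and a single change at a single place says little about the rest of the shared core.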